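Shrinking the ring-bearing arm to an ethyl group

This account rests on a few compounds, and the source may have more. Where it says the series, first, only, none or still open, it means among the compounds named here.

Compound 2 `COc1ccc([C@@H]2CC(=O)c3c(O)cc(OCc4cn(Cc5ccccc5Cl)nn4)cc3O2)cc1O` carries, on the nitrogen of its triazole-linked side arm, a 2-chlorobenzyl group. In a functional assay on RAW264.7 cells (Mus musculus) for inhibition, read by Griess assay, with stated times of 2 h and 24 h (a lower number here means a stronger inhibitor, a higher number a weaker inhibitor), compound 2 gives 6140 nM. Among the three measured compounds this is the second highest number: compound 3 `COc1ccc([C@@H]2C/C(=N\O)c3c(O)cc(OCc4cn(-c5ccccc5)nn4)cc3O2)cc1O` gives 6130 nM, within the scatter of compound 2, while compound 1 `COc1ccc([C@@H]2C/C(=N\O)c3c(O)cc(OCc4cn(Cc5ccccc5C)nn4)cc3O2)cc1O` gives 18000 nM, the highest of the three.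

Compound 4 `CCn1cc(COc2cc(O)c3c(c2)O[C@H](c2ccc(OC)c(O)c2)CC3=O)nn1` differs from compound 2 in one place: methyl in place of 2-chlorophenyl on a saturated chain carbon bound to an aromatic nitrogen. For the measured compounds named here, no measured pair repeats this change exactly. The closest guide is the step from compound 1 to compound 3, where a smaller group replaced a larger one on the same aromatic nitrogen and gave a 2.9-fold lower number from compound 1 to compound 3 (0.47 log units; beyond the scatter). That step was modest, and it concerns a different pair of groups, so only a loose parallel can be drawn. On that basis the number for compound 4 is expected to change little, perhaps drifting somewhat lower, as a 1.2-fold lower number from compound 2 to compound 4 (0.09 log units; within the scatter). The estimate for compound 4 is therefore 5000 nM, with a range from 1800 nM to 14000 nM.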

Compound 4, half-maximal inhibitory concentration: 15000 nM
Compound 4: the middle estimate sits 3.0-fold (0.48 log units) below what was measured, and the stated range ends below it.
By their numbers in this assay, from the lowest: compounds 3 and 2 (each within the scatter of the next); then compounds 4 and 1 (each within the scatter of the next).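

In this assay, for the compounds shown here, cutting the 2-chlorobenzyl arm down to ethyl gives a 2.4-fold higher number from compound 2 to compound 4 (0.39 log units; beyond the scatter), the first step here in which the side arm loses its ring altogether. Shrinking this arm therefore does not always lower the number: the earlier step, a 2.9-fold lower number from compound 1 to compound 3 (0.47 log units; beyond the scatter), went the other way, but there a phenyl ring remained and the core carried a different group. No measurement shown here explains the rise.

As far as these compounds go, it stays open whether the ring itself, the chlorine or simply the length of the arm matters most, and a plain benzyl group or a butyl chain on the same core would help separate these. Whether the change from 2-chlorobenzyl to ethyl acts in the same direction on the core of compound 1 also remains unanswered.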